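The compounds below may be only part of what the source reports. "The series", "measured", "known", "first", "only" and "open" are said of these compounds alone.

Measured so far:
compound 1, `O=C(Nc1cccc(-n2cc(-c3ccncc3)c(-c3cc(O)cc(Cl)c3)n2)c1)Nc1ccc(Cl)c(Cl)c1`, 93%
compound 2, `COc1cc(Cl)cc(-c2nn(-c3cccc(NC(=O)Nc4cc(C(F)(F)F)cc(C(F)(F)F)c4)c3)cc2-c2ccncc2)c1`, 96%

In a functional assay on RXF 393 cells (Homo sapiens) for inhibition, read by sulforhodamine B assay, with a stated time of 48 h, tested at 0.01 uM (a lower number here means a stronger effect, a higher number a weaker effect of the compound at the concentration tested), compound 1 gives 93%. Compound 2 gives 96% in this assay, and the two numbers lie within the scatter of each other, so neither compound can be set apart from the other on this read-out; both leave most of the cell growth untouched at the concentration tested.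

Compound 3, `COc1cc(Cl)cc(-c2nn(-c3cccc(NC(=O)Nc4ccc(Cl)c(Cl)c4)c3)cc2-c2ccncc2)c1`, has not yet been measured in this assay. It differs from compound 1 in one place: methyl in place of hydrogen on an oxygen on an aromatic ring. Compound 2 carries the same methoxy group, and of the pair of compound 2 and compound 1 only their two values show, which sit close together.

Within the data shown here, no step between measured compounds is available for this change. The expectation for this assay is therefore no step beyond the scatter, in either direction. Compound 3 is expected to give 94%, with a range from 84% to 102%. The step of a number 1 percentage points higher from compound 1 to compound 3 (within the scatter) is thus estimated to be small.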

Compound 3, a percentage reported as activity, at one concentration (the size of the read-out at that concentration, not a potency): 100%
Compound 3: the middle estimate sits 6 percentage points below what was measured; low and high end bracket the measured number.
By their numbers in this assay, from the lowest: compounds 1, 2 and 3 (each within the scatter of the next).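

Among these compounds, replacing hydrogen with methyl on the oxygen, which turns 3-chloro-5-hydroxyphenyl into 3-chloro-5-methoxyphenyl, gives the first direct reading of this change in this assay: a number 7 percentage points higher from compound 1 to compound 3 (within the scatter), so the change does not set the two compounds apart. With compound 1 at 93% and compound 3 at 100%, both compounds leave most of the cell growth untouched, and this single low concentration offers little room to show what the change does to a stronger effect. No measurement is available that would explain the step or link it to a property of either group.

As far as these compounds go, whether a longer chain such as ethoxy on the same oxygen, or an amine in place of the hydroxy group, would move the read-out beyond the scatter in this assay remains open. Also open, from the compounds shown here alone, is whether hydroxy and methoxy would still read alike at higher concentrations, where the shared core might give a larger effect.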